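The compounds below may be only part of what the source reports. "The series", "measured", "known", "first", "only" and "open" are said of these compounds alone.

Compound 1, `COc1ccc2c(c1)C(n1ccccc1=O)=CC(C)(C)O2`, gives 5.99.
Compound 2, `CC(=O)c1ccc2c(c1)C(n1ccccc1=O)=CC(C)(C)O2`, gives 6.65.
Compound 3, `CC1(C)C=C(n2ccccc2=O)c2cc(OC(=O)Nc3ccccc3)ccc2O1`, gives 4.89.

These three compounds share one core and were compared in a functional assay (trachea) with Rattus norvegicus as the target; on this read-out higher numbers stand for higher potency (the scale is a negative logarithm) and lower numbers for lower potency. Compound 3 stands lowest of the three: the step of a number 1.10 log units lower from compound 1 to compound 3 (beyond the scatter) separates it from its nearest neighbour, and compound 2 sits higher still, reached through the step of a number 0.66 log units higher from compound 1 to compound 2 (beyond the scatter).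

Compound 4, `CC1(C)C=C(n2ccccc2=O)c2cc(OS(=O)(=O)F)ccc2O1`, has not yet been measured. It differs from compound 3 in a single place: fluorosulfonyl in place of phenylcarbamoyl on an oxygen on an aromatic ring. This change sits on the same oxygen where the step of a number 1.10 log units lower from compound 1 to compound 3 (beyond the scatter) took place, so that large step bears most directly on it; the step of a number 0.66 log units higher from compound 1 to compound 2 (beyond the scatter) altered another part of the core and bears only loosely. Because the step of a number 1.10 log units lower from compound 1 to compound 3 (beyond the scatter) was a large drop on attaching a group far bigger than the one now entering, a partial return toward the level of compound 1 is expected. Compound 4 is therefore estimated to give 5.6 in this assay, within the range 4.9 to 6.3, corresponding to an expected step of a number 0.71 log units higher from compound 3 to compound 4 (beyond the scatter).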

Compound 4, logarithm of the reciprocal of the active concentration, log(1/C): 7.22
Compound 4: middle estimate off by 1.62 log units, on the low side, and the stated range ends below it.
By their numbers in this assay, from the lowest: compound 3; then compound 1; then compound 2; then compound 4.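

At this oxygen on an aromatic ring, the group can push the number in this assay upward as well as down: the earlier change here gave only a drop, whereas replacing methyl with fluorosulfonyl gives a number 1.23 log units higher from compound 1 to compound 4 (beyond the scatter) and a clear gain. Replacing phenylcarbamoyl with fluorosulfonyl gives a number 2.33 log units higher from compound 3 to compound 4 (beyond the scatter) and shows how widely this one place can move the read-out, while a number 0.57 log units higher from compound 2 to compound 4 (beyond the scatter) places the (fluorosulfonyl)oxy group ahead of acetyl, the best earlier group on that aromatic carbon. No measurement is available to explain this rise.

As far as these compounds go, it remains open whether the gain needs the fluorine, which methanesulfonyl on the same oxygen could test. A free hydroxyl or a trifluoromethanesulfonyl group at this oxygen would also show how far the trend holds.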